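From cyclopropylmethyl to 4-fluorobenzyl on the sulfur

The compounds below may be only part of what the source reports. "The series", "measured", "known", "first", "only" and "open" are said of these compounds alone.

Within the data shown here, in a functional assay on HGC-27 cells (Homo sapiens) for inhibition, read by MTT assay, with a stated time of 72 h (a lower number here means a stronger inhibitor, a higher number a weaker inhibitor), compound 1 `Cc1cc(N2CC[C@@H](C)[C@@H](N(C)c3ncnc4[nH]ccc34)C2)n2nc(SCC3CC3)nc2n1` gives 21400 nM, the only exact value in this small set. Compound 2 `C[C@@H]1CCN(c2cc(-c3ccccc3)nc3ncnn23)C[C@@H]1N(C)c1ncnc2[nH]ccc12` is reported only as a limit, > 100000 nM. Compound 3 `Cc1nc2nc(SCc3ccc(Cl)cc3)nn2c(N2CC[C@@H](C)[C@@H](N(C)c3ncnc4[nH]ccc34)C2)c1C` is also reported only as a limit, > 100000 nM. Taken together, this is the limit of > 100000 nM in this assay, at which 2 of the 3 values shown sit.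

Compound 4 `Cc1cc(N2CC[C@@H](C)[C@@H](N(C)c3ncnc4[nH]ccc34)C2)n2nc(SCc3ccc(F)cc3)nc2n1` keeps the core of compound 1 and places 4-fluorophenyl in place of cyclopropyl on a saturated chain carbon bound to a sulfur. The same difference reads as cyclopropylmethyl to 4-fluorobenzyl. Among the measured compounds shown here, no measured step isolates this change, so its size in this assay remains an expectation. With compound 1 at 21400 nM as the reference, a modest weakening is expected, slightly beyond the scatter. The estimated change is a 2.3-fold higher number from compound 1 to compound 4 (0.37 log units; beyond the scatter). For compound 4 the expected value is 50000 nM, with an estimated range of 15000 nM to 100000 nM.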

Compound 4, half-maximal inhibitory concentration: 26000 nM
Compound 4: the middle estimate sits 1.9-fold (0.28 log units) above what was measured; measured number inside the range.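

On a saturated chain carbon bound to a sulfur, 4-fluorophenyl in place of cyclopropyl gives a 1.2-fold higher number from compound 1 to compound 4 (0.08 log units; within the scatter) in this assay. Among these compounds, this is the first readable step at this position: an aromatic ring of carbon with more heavy atoms enters where a three-membered non-aromatic ring stood, and the two numbers still lie within the scatter of each other. Compound 2 and compound 3 remain limits and add no step here: the limit of > 100000 nM in this assay, at which 2 of the 4 values shown sit.

From the compounds shown here alone, with a single step at this position, it remains open whether the fluorine plays any part, which an unsubstituted benzyl on the sulfur would separate from the effect of the aromatic ring itself. Also open, going by these compounds, is whether a chain ending in an amine or a carboxylic acid at this place would give a step beyond the scatter.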